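Adding a second chlorine to two sulfonyl anilide series

The source may report more compounds than this note shows. Statements on the series, on what has been measured and on what is new or still open speak of the compounds shown alone.

Compound 1 `Cc1c(S(=O)(=O)N/C(=N\O)Nc2ccc(Cl)cc2)sc2ccc(Cl)cc12` carries a single chloro group on its aniline ring. In a functional assay on TSGH 8302 cells (Homo sapiens) for cytotoxicity (on this read-out higher numbers stand for weaker inhibition and lower numbers for stronger inhibition), compound 1 gives 44 ug/mL. Compound 2 `Cc1c(S(=O)(=O)N/C(=N\O)Nc2ccc(Cl)c(Cl)c2)sc2ccc(Cl)cc12` carries a second chloro group on that ring; the change is chloro in place of hydrogen on an aromatic carbon. Compound 2 reaches only the limit of the assay in this assay, recorded as > 300 ug/mL. The step is therefore an at least 6.8-fold higher number from compound 1 to compound 2 (0.83 log units; beyond the scatter), and it rests on (the limit of > 300 ug/mL in this assay, at which 1 of the 3 values shown sits).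

Compound 3 `Cc1ccc(S(=O)(=O)/N=C(\S)Nc2ccc(Cl)cc2)cc1` is built on a different core, again with a single chloro group on its aniline ring; the difference between the two cores is not broken down here. In this assay compound 3 gives 125 ug/mL, a higher number than compound 1 and beyond the scatter, so compound 3 is the weaker of the two measured ones.

Compound 4 `Cc1ccc(S(=O)(=O)/N=C(\S)Nc2ccc(Cl)c(Cl)c2)cc1` has not been measured. It stands to compound 3 as compound 2 stands to compound 1: the change is chloro in place of hydrogen on an aromatic carbon, the same change made on the other core. Since that change produced an at least 6.8-fold higher number from compound 1 to compound 2 (0.83 log units; beyond the scatter), a step of similar direction is expected here, while the different core leaves its size uncertain. The expected step in this assay is a 3.2-fold higher number from compound 3 to compound 4 (0.51 log units; beyond the scatter). Compound 4 is therefore estimated at 400 ug/mL in this assay, within a range from 130 ug/mL to 1200 ug/mL, with a real chance that only a limit is reported.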

Compound 4, half-maximal inhibitory concentration: 55 ug/mL
For compound 4 the middle estimate is 7.3-fold (0.86 log units) above the measured one; measured number below the stated range.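

In this assay, the added chloro group gives a 2.3-fold lower number from compound 3 to compound 4 (0.36 log units; beyond the scatter), so on this core the number falls, while on the core of compound 1 the same change made it rise. A change that looks identical on paper therefore cannot be carried from one core to the other here, neither in direction nor in size: the same change on two cores in this assay, an at least 6.8-fold higher number (0.83 log units; beyond the scatter) from compound 1 to compound 2 and a 2.3-fold lower number (0.36 log units; beyond the scatter) from compound 3 to compound 4, at least 15-fold (1.19 log units) apart, beyond the scatter of two such steps
Compound 2 is recorded only as a limit, so the step on its core has a lower bound rather than an exact size, and with just one pair on each core the data show that the cores behave differently but not why: the limit of > 300 ug/mL in this assay, at which 1 of the 4 values shown sits.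

It remains open which part of the two cores decides the direction of the step, since the cores are not broken down into single changes among the compounds shown. On these data alone, it also remains open whether a different group in the same place, such as a methoxy group or an amine, would split between the two cores as the chloro group does, or would move the number the same way on both.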